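Swapping Bromo for Iodo: What One Step Can Suggest

The compounds below may be only part of what the source reports. "The series", "measured", "known", "first", "only" and "open" are said of these compounds alone.

Among the measured compounds shown here, in a functional assay on HOP-62 cells (Homo sapiens) for inhibition, read by sulforhodamine B assay, with a stated time of 48 h (a lower number here means a stronger inhibitor of growth, a higher number a weaker inhibitor of growth), compound 2 `NC(=O)c1cc(Br)ccc1NC(=O)/C=C/c1ccccc1` gives 1510 nM, the lower of the two numbers measured so far. For the measured compounds named here, the only other measured compound, compound 1 `Cc1ccc(NC(=O)/C=C/c2ccccc2)c(C(N)=O)c1`, gives 7740 nM, so compound 2 is the stronger inhibitor of growth of this pair. The next compound, compound 3 `NC(=O)c1cc(I)ccc1NC(=O)/C=C/c1ccccc1`, keeps the core of compound 2 and alters one group: iodo in place of bromo on an aromatic carbon. Iodo takes the place of bromo on an aromatic carbon, meta to a carbamoyl group and para to a large group.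

Going by the values given here, only one measured step bears on this change: a 5.1-fold lower number from compound 1 to compound 2 (0.71 log units; beyond the scatter), where bromo replaced methyl on that same aromatic carbon. Among the compounds with values here, this modest step is the only guide available, and no measurement yet shows what iodo does. A single step sets no trend, so only a small further drop is expected, and it may well stay within the scatter. The estimated step is a 1.3-fold lower number from compound 2 to compound 3 (0.10 log units; within the scatter). The expected value for compound 3 is 1200 nM, with a likely range of 500 nM to 3000 nM.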

Compound 3, concentration for 50% growth inhibition: 800 nM
Compound 3: the middle estimate sits 1.5-fold (0.18 log units) above what was measured, and the stated range covers the measured number.
By their numbers in this assay, from the lowest: compounds 3 and 2 (each within the scatter of the next); then compound 1.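

At this aromatic carbon, the swap of bromo for iodo in this assay gives a 1.9-fold lower number from compound 2 to compound 3 (0.28 log units; within the scatter) and so does not separate the two groups, which means a newly tested atom of this kind can stand here without a change that exceeds normal assay variation. Measured against methyl, iodo gives a 9.7-fold lower number from compound 1 to compound 3 (0.99 log units; beyond the scatter) and sits alongside the earlier 5.1-fold lower number from compound 1 to compound 2 (0.71 log units; beyond the scatter) as a second step away from methyl that lies beyond the scatter, so the difference from methyl no longer rests on bromo alone. No supporting data bear on what lies behind these numbers.

On these data alone, the three compounds place only methyl, bromo and iodo on this carbon, so what chloro, a methoxy group or an amine would do at the same place remains open. As far as these compounds go, whether the step away from methyl would persist with a carboxylic acid in place of the carbamoyl group also remains open, since that group is the same in all three compounds.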